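A few compounds are considered here, and "the series" means these few. Any claim that something is new, unique, unknown or untested is made for them only; others in the source may bear on it.

Working notes on the series. Compound 1 `CCCCCCCC(=O)OCC1CN(C(=O)c2cc(OC)c(OC)c(OC)c2)CCN1C(=O)c1cc(OC)c(OC)c(OC)c1` is one of two compounds with a single number in a functional assay (Oryctolagus cuniculus) for inhibition of platelet-activating factor receptor (Cavia porcellus); on this read-out higher numbers stand for weaker inhibition and lower numbers for stronger inhibition; compound 1 gives 310 nM, the higher of those two numbers. Compound 3 `CCCCNC(=O)OCC1CN(C(=O)c2cc(OC)c(OC)c(OC)c2)CCN1C(=O)c1cc(OC)c(OC)c(OC)c1` gives 240 nM in this assay, and the step of a 1.3-fold lower number from compound 1 to compound 3 (0.11 log units; within the scatter) stays within the scatter, so neither compound can be placed above the other. Compound 2 `COc1cc(C(=O)N2CCN(C(=O)c3cc(OC)c(OC)c(OC)c3)C(COC(=O)C(C)(C)C)C2)cc(OC)c1OC` has been measured repeatedly in this assay: compound 2 gives 100 nM; 100 nM; 120 nM (3 entries), and the several entries of compound 2 in this assay, 100 nM; 100 nM; 120 nM (3 entries) shows how closely repeat entries of one compound agree on this read-out. Among the compounds with values here, no step between compound 2 and the other two is computed, so their values are only set side by side.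

Compound 4 `CCCCCCCCNC(=O)OCC1CN(C(=O)c2cc(OC)c(OC)c(OC)c2)CCN1C(=O)c1cc(OC)c(OC)c(OC)c1` has not yet been measured in this assay. It differs from compound 1 as follows: octylamino in place of heptyl on a carbonyl carbon. Within the data shown here, the only measured step that bears on this change is a 1.3-fold lower number from compound 1 to compound 3 (0.11 log units; within the scatter), in which butylamino took the place of heptyl on the same carbonyl carbon without moving the number beyond the scatter. With octylamino now taking that place, the expectation for compound 4 is likewise a small step, a 1.3-fold lower number from compound 1 to compound 4 (0.11 log units; within the scatter), toward a lower number and not beyond the scatter. Compound 4 is therefore estimated at 240 nM in this assay, with a range from 110 nM to 520 nM.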

Compound 4, half-maximal inhibitory concentration: 370 nM
Compound 4: middle estimate off by 1.5-fold (0.19 log units), on the low side; the range from low to high includes it.
By their numbers in this assay, from the lowest: compounds 3, 1 and 4 (each within the scatter of the next).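

In this assay, octylamino on this carbonyl carbon gives a 1.2-fold higher number from compound 1 to compound 4 (0.08 log units; within the scatter), so the heptyl group has now been replaced by two different amino-linked chains, butylamino and octylamino, without the number leaving the scatter. The second new comparison, a 1.5-fold higher number from compound 3 to compound 4 (0.19 log units; within the scatter), shows that butyl added on the saturated chain also stays within the scatter, so compounds 1, 3 and 4 cannot be ordered and, across these three compounds, the read-out does not resolve either the heptyl-to-amino change or the chain length of the two amino groups. Repeat entries of a single compound give a direct view of how far this read-out agrees with itself, and the gaps among these three compounds are read against it: the several entries of compound 2 in this assay, 100 nM; 100 nM; 120 nM (3 entries)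

Still open, as far as these compounds go, is whether a much shorter chain such as methylamino, a carboxylic acid at the end of the chain, or a phenyl ring in this place would move the number beyond the scatter. Within the data shown here, compound 2 has no computed step to compounds 1, 3 or 4, so how its branched group compares with these chains also remains unresolved.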